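The compounds below may be only part of what the source reports. "The series", "measured", "known", "first", "only" and "open" are said of these compounds alone.

Measured compounds:
Compound 1, `COc1ccc(C(=O)/C(=C/c2ccc([N+](=O)[O-])cc2)CCOC(C)=O)cc1`: in a functional assay on MCF7 cells (Homo sapiens) for inhibition, read by XTT assay, with a stated time of 48 h (on this read-out lower numbers stand for stronger inhibition and higher numbers for weaker inhibition), compound 1 gives > 100000 nM, which is a limit of the assay and not a number.
Compound 2, `COc1ccc(C(=O)/C(=C/c2ccc([N+](=O)[O-])cc2)CC(C)C)cc1`: in this assay compound 2 gives > 100000 nM, likewise a limit of the assay.

Compound 2 thus stands only at a limit, and the other value shown sits at the same limit (the limit of > 100000 nM in this assay, at which 2 of the 2 values shown sit). Among the compounds with values here, the one measured step, a step that the two limits leave unreadable from compound 1 to compound 2, cannot be read because the limit of > 100000 nM in this assay, at which 2 of the 2 values shown sit, covers both of its ends.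

Compound 3, `CCN(CC)C/C(=C\c1ccc([N+](=O)[O-])cc1)C(=O)c1ccc(OC)cc1`, differs from compound 2 by diethylamino in place of isopropyl on a saturated chain carbon bound to a double-bonded chain carbon; cut one bond further out, the same difference reads isobutyl to (diethylamino)methyl. Within the data shown here, no measured step gives a readable size for an exchange at this position, so the expectation rests on the limits alone, with no direction beyond the scatter claimed. The expected step is an at least 1.6-fold lower number from compound 2 to compound 3 (0.22 log units; that floor lies within the scatter). Compound 3 is expected in this assay at 60000 nM, with a range from 10000 nM to 200000 nM, and a fair chance that only a limit is reported again.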

Compound 3, half-maximal inhibitory concentration: 4300 nM
Estimate against measurement, compound 3: 14-fold (1.14 log units) above; the whole stated range lies above it.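

Diethylamino, on a saturated chain carbon bound to a double-bonded chain carbon, gives the first readable result of the series in this assay: an at least 23-fold lower number from compound 2 to compound 3 (1.36 log units; beyond the scatter) against isopropyl, and an at least 23-fold lower number from compound 1 to compound 3 (1.36 log units; beyond the scatter) against acetoxymethyl. The step between compound 1 and compound 2 still cannot be read, so only compound 3 shows that an exchange at this position can move the number. Both readable steps are floors and not full sizes, because each starts from a limit: the limit of > 100000 nM in this assay, at which 2 of the 3 values shown sit.

Among the compounds shown, only compound 3 carries an amine at this position, so it stays open whether the nitrogen or the larger diethylamino group goes with the change. Dimethylamino, piperidine, morpholine or a plain pentyl chain at this position would bear on that question.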